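Notes on compound 1 and its side-chain analogue compound 3

The source may report more compounds than this note shows. Statements on the series, on what has been measured and on what is new or still open speak of the compounds shown alone.

Measured so far:
compound 1, `Fc1ccc([C@@H]2CNC[C@H]2c2nc(N3CCC3)c3cc(-c4cn[nH]c4)ccc3n2)cc1`: 71 nM
compound 2, `Cc1n[nH]cc1-c1ccc2nc([C@@H]3CNC[C@H]3c3ccccc3)[nH]c(=O)c2c1`: 7 nM

In an in vitro assay on Sf9 cells for inhibition of Rho-associated protein kinase 2 (Homo sapiens), read by TR-FRET, with a stated time of 25 min (a lower number here means a stronger inhibitor, a higher number a weaker inhibitor), compound 1 gives 71 nM, the higher of the two numbers measured; compound 2, `Cc1n[nH]cc1-c1ccc2nc([C@@H]3CNC[C@H]3c3ccccc3)[nH]c(=O)c2c1`, sits at 7 nM, a gap beyond the usual scatter. The two differ in more than one place, so no single change accounts for it.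

Compound 3, `CN(C)CCNc1nc([C@@H]2CNC[C@H]2c2ccc(F)cc2)nc2ccc(-c3cn[nH]c3)cc12`, follows from compound 1 by one change: (2-(dimethylamino)ethyl)amino in place of azetidin-1-yl on an aromatic carbon. Within the data shown here, no measured pair shows this change, so the expected step from compound 1 to compound 3 in this assay, a 1.4-fold lower number from compound 1 to compound 3 (0.15 log units; within the scatter), is taken as small and not clearly beyond the scatter. Compound 3 is expected at 50 nM, within 15 nM to 180 nM.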

Compound 3, half-maximal inhibitory concentration: 371 nM
Beside the measured number, compound 3's estimate is 7.4-fold (0.87 log units) below it, outside the stated range (above it).
By their numbers in this assay, from the lowest: compound 2; then compound 1; then compound 3.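

In this assay the exchange of azetidin-1-yl for (2-(dimethylamino)ethyl)amino gives a 5.2-fold higher number from compound 1 to compound 3 (0.72 log units; beyond the scatter) and so shows that this position of the shared core responds to the group it carries. Compound 1 and compound 2 could not show this, as they differ in more than one place. No measurement here offers an explanation for the step.

Open, as far as these compounds go, is whether the ring loss or the terminal dimethylamino group accounts for the step. Also open, from the compounds shown here alone, is how a morpholine, a piperidine or a shorter aminoethyl chain would read here.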